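Benzyl in Place of Difluorophenyl on the Amine Nitrogen

The source may hold more compounds than are shown below. What is called first, only, known or untested is meant among the compounds shown, and "the series" means these compounds.

Compound 1 `COc1ccc(N/C(CCNC2=CC(=O)c3ccccc3C2=O)=N\S(=O)(=O)c2ccc(C)cc2)cc1` — 6030 nM
Compound 2 `Cc1ccc(S(=O)(=O)/N=C(/CCNC2=CC(=O)c3ccccc3C2=O)Nc2ccccc2[N+](=O)[O-])cc1` — 3090 nM
Compound 3 `Cc1ccc(S(=O)(=O)/N=C(/CCNC2=CC(=O)c3ccccc3C2=O)Nc2ccc(F)c(F)c2)cc1` — 9420 nM

Of the compounds shown here, three sharing one core have been measured in a functional assay on MCF7 cells (Homo sapiens) for cytotoxicity, read by MTT assay, with a stated time of 48 h; on this read-out lower numbers stand for stronger inhibition and higher numbers for weaker inhibition. Compound 3 stands at the highest number of the three; its nearest neighbour is compound 1, and the step of a 1.6-fold higher number from compound 1 to compound 3 (0.19 log units; within the scatter) stays within the scatter, while the step of a 3.0-fold higher number from compound 2 to compound 3 (0.48 log units; beyond the scatter) is the only one beyond it. The step of a 2.0-fold lower number from compound 1 to compound 2 (0.29 log units; within the scatter) between the other two also stays within the scatter.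

Compound 4 `Cc1ccc(S(=O)(=O)/N=C(/CCNC2=CC(=O)c3ccccc3C2=O)NCc2ccccc2)cc1` differs from compound 3 by benzyl in place of 3,4-difluorophenyl on an amine nitrogen. The measured steps all exchange one aryl group for another on that same nitrogen and were small, the largest being a 3.0-fold higher number from compound 2 to compound 3 (0.48 log units; beyond the scatter). None of them introduces a benzyl, so they bear on the new change only by showing that this position has so far tolerated exchanges without large shifts in this assay. A step of at most modest size is therefore expected, with no confident direction; if anything, the number is expected to settle back toward the middle of the three measured values rather than rise further.

Compound 4 is expected to give 6500 nM, within a range of 2500 nM to 18000 nM, corresponding to an estimated step of a 1.4-fold lower number from compound 3 to compound 4 (0.16 log units; within the scatter).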

Compound 4, half-maximal inhibitory concentration: 3630 nM
Beside the measured number, compound 4's estimate is 1.8-fold (0.25 log units) above it, within the range that was stated.
By their numbers in this assay, from the lowest: compounds 2, 4, 1 and 3 (each within the scatter of the next, the first and the last beyond it).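

Benzyl is the first group on this amine nitrogen that is not a substituted phenyl, and in this assay the position accepts it, with a 2.6-fold lower number from compound 3 to compound 4 (0.41 log units; beyond the scatter) as a modest step that sets compound 3 apart from compound 4 just as it is set apart from compound 2. The other two steps, a 1.2-fold higher number from compound 2 to compound 4 (0.07 log units; within the scatter) and a 1.7-fold lower number from compound 1 to compound 4 (0.22 log units; within the scatter), both stay within the scatter, so moving from a directly attached aryl group to benzyl brings no new level of cytotoxicity on this read-out and leaves compound 3 as the only one that separates from any other compound. Nothing at hand accounts for the step away from compound 3.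

The compounds shown leave open whether this nitrogen keeps the same numbers with a group that has no aromatic ring, such as cyclohexyl, or with a longer chain, such as phenethyl. They also leave open whether 3,4-difluorobenzyl would stay with compound 4 or move toward compound 3, which would separate the effect of the two fluorines from that of the added carbon.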